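Shortening a long chain on a dithioacetal diacid

The source may hold more compounds than are shown below. What is called first, only, known or untested is meant among the compounds shown, and "the series" means these compounds.

Three compounds sharing one core are compared here, differing only in the length of a saturated chain attached to the aromatic ring. Compound 1 `CCCCCCCCCCCCc1ccccc1C(SCCC(=O)O)SCCC(=O)O` carries the longest chain, compound 2 `CCCCCCCCCCc1ccccc1C(SCCC(=O)O)SCCC(=O)O` a shorter one, and compound 3 `CCCCCCCCc1ccccc1C(SCCC(=O)O)SCCC(=O)O` the shortest. Among the compounds with values here, in an assay on membranes from lung (Cavia porcellus) for binding affinity to cysteinyl leukotriene receptor (Homo sapiens) (on this read-out higher numbers stand for weaker inhibition and lower numbers for stronger inhibition), compound 1 gives 445 nM, while compound 2 gives 1180 nM, the highest of the two numbers so far; the step of a 2.7-fold higher number from compound 1 to compound 2 (0.42 log units; beyond the scatter) shows that trimming the chain weakened inhibition. The move from compound 2 to compound 3 repeats that kind of change: hydrogen in place of ethyl on a saturated chain carbon, eight bonds along the chain from an aromatic carbon. Within the data shown here, because the only step of this kind, a 2.7-fold higher number from compound 1 to compound 2 (0.42 log units; beyond the scatter), was modest and pointed toward weaker inhibition, a similar shift is expected, giving the estimated step of a 2.5-fold higher number from compound 2 to compound 3 (0.39 log units; beyond the scatter). Compound 3 is therefore estimated at 2900 nM, with a plausible range from 1200 nM to 7000 nM.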

Compound 3, inhibition constant: 5670 nM
Compound 3: the middle estimate sits 2.0-fold (0.29 log units) below what was measured; measured number inside the range.
By their numbers in this assay, from the lowest: compound 1; then compound 2; then compound 3.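

In this assay a second trimming of the chain also weakens inhibition, with a 4.8-fold higher number from compound 2 to compound 3 (0.68 log units; beyond the scatter) showing that the first loss was not a single event. Taken together, the two trimmings amount to a 13-fold higher number from compound 1 to compound 3 (1.11 log units; beyond the scatter) and mark a large loss, and none of the three compounds goes against the trend that a shorter chain gives weaker inhibition. The latest step reads larger than a 2.7-fold higher number from compound 1 to compound 2 (0.42 log units; beyond the scatter) but two steps alone cannot show whether each further trimming truly costs more than the one before.

Nothing among the data given offers an explanation for this dependence on chain length. The compounds shown leave open whether a longer chain than that of compound 1 would strengthen inhibition further, and how a chain ending in an amine or a carboxylic acid would behave.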